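Notes on the pyrrolidine amine and a piperidine replacement

The compounds below may be only part of what the source reports. "The series", "measured", "known", "first", "only" and "open" are said of these compounds alone.

Compound 3 `NC1CCN(c2ccc3cc(NC(=O)CCc4ccc(C(F)(F)F)cc4)ccc3n2)C1` gives 200 nM in a functional assay on HEK293 cells for activation of melanin-concentrating hormone receptor 1 (Rattus norvegicus), read by inositol phosphate accumulation (on this read-out higher numbers stand for an effect only at larger amounts of compound and lower numbers for an effect already at smaller amounts), the second highest of the three numbers; compound 1 `CC(C)C(=O)NC1CCN(c2ccc3cc(NC(=O)CCc4ccc(C(F)(F)F)cc4)ccc3n2)C1` gives 90 nM and compound 2 `CC(=O)NC1CCN(c2ccc3cc(NC(=O)CCc4ccc(C(F)(F)F)cc4)ccc3n2)C1` gives 440 nM. The measured steps all vary the acyl group on the amine nitrogen: a 4.9-fold higher number from compound 1 to compound 2 (0.69 log units; beyond the scatter), a 2.2-fold higher number from compound 1 to compound 3 (0.35 log units; beyond the scatter), a 2.2-fold lower number from compound 2 to compound 3 (0.34 log units; beyond the scatter). Compound 4 `O=C(CCc1ccc(C(F)(F)F)cc1)Nc1ccc2nc(N3CCCCC3)ccc2c1` instead changes the ring itself: piperidin-1-yl in place of 3-aminopyrrolidin-1-yl on an aromatic carbon. Going by the values given here, no measured step touches the ring or removes the amine, so the expectation rests only on the spread seen across compounds 1 to 3, which is modest in both directions. A modest rise in this assay is expected, a 2.3-fold higher number from compound 3 to compound 4 (0.35 log units; beyond the scatter), with wide uncertainty. Compound 4 is estimated at 450 nM, range 100 nM to 2500 nM.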

Compound 4, half-maximal effective concentration: 110 nM
Compound 4: middle estimate off by 4.1-fold (0.61 log units), on the high side; the range from low to high includes it.
By their numbers in this assay, from the lowest: compounds 1, 4 and 3 (each within the scatter of the next, the first and the last beyond it); then compound 2.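

In this assay, piperidin-1-yl, with 0 hydrogen-bond donors, does not clearly differ from 3-aminopyrrolidin-1-yl at this aromatic carbon: a 1.8-fold lower number from compound 3 to compound 4 (0.26 log units; within the scatter). The isopropylcarbonyl-capped amine gives the same picture, with a 1.2-fold higher number from compound 1 to compound 4 (0.09 log units; within the scatter), whereas the acetyl-capped amine stands apart, with a 4.0-fold lower number from compound 2 to compound 4 (0.60 log units; beyond the scatter). Nothing available explains these results.

Ring size and the amine change together in this replacement; pyrrolidin-1-yl without the amine would separate the two. Going by these compounds, how 4-aminopiperidin-1-yl or morpholin-4-yl behaves at this carbon remains open.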